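The source may report more compounds than this note shows. Statements on the series, on what has been measured and on what is new or still open speak of the compounds shown alone.

Four related compounds are compared in a functional assay on HT-29 cells (Homo sapiens) for cytotoxicity, read by MTT assay, with a stated time of 72 h; a higher number here means that more compound is tolerated, a lower number that less compound is tolerated. Compound 1 `CSc1ccc(CNc2nc(SC)nc3ncccc23)cc1` gives 8750 nM in this assay. Compound 2 `COc1ccc(CNc2nc(SC)nc3ncccc23)cc1` reaches only the limit of this assay, > 100000 nM, so no number is known for it. The change from compound 2 to compound 1 is methylsulfanyl in place of methoxy on an aromatic carbon, and it brought an at least 11-fold lower number from compound 2 to compound 1 (1.05 log units; beyond the scatter). Compound 3 `COc1ccc(CNc2nc(SC)nc3ccccc23)cc1` also stops at the limit of this assay, > 100000 nM. The difference between the core of compound 3 and the core of compound 2 is not broken down here. Compound 4 `CSc1ccc(CNc2nc(SC)nc3ccccc23)cc1` is not yet measured; it differs from compound 3 by methylsulfanyl in place of methoxy on an aromatic carbon, the same change. A step of an at least 6.6-fold lower number from compound 3 to compound 4 (0.82 log units; beyond the scatter) is expected, because an at least 11-fold lower number from compound 2 to compound 1 (1.05 log units; beyond the scatter) was seen in this assay, though compound 3 starts from a limit. Compound 4 is therefore estimated at 15000 nM in this assay, between 5000 nM and 100000 nM.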

Compound 4, concentration lethal to 50% of the cells: > 100000 nM
Compound 4 was reported as a limit; the forecaster's own chance of this, stated with the estimate: 30%; middle value at least 6.6-fold (0.82 log units) away from the limit.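

In this assay compound 3 and compound 4 both stop at a limit, so no step can be read between them. Left open is whether methylsulfanyl in place of methoxy changes the number at all on the core of compound 3, as it did on the core of compound 2.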